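The compounds below may be only part of what the source reports. "The series", "measured", "known", "first", "only" and "open" are said of these compounds alone.

Compound 3, with the structure `COC(=O)c1cccc(CSc2ccc3c(C)cc(=O)oc3c2)c1`, is the only one of the three measured compounds that returns a number in a functional assay on A549 cells (Homo sapiens) for antiproliferative activity, read by sulforhodamine B assay, with a stated time of 72 h (on this read-out lower numbers stand for stronger inhibition of growth and higher numbers for weaker inhibition of growth), where compound 3 gives 7700 nM. Compound 1, with the structure `Cc1cc(=O)oc2cc(SCc3ccncc3)ccc12`, sits at a limit of this assay, giving > 35200 nM (the limit of > 35200 nM in this assay, at which 1 of the 3 values shown sits). Compound 2, with the structure `Cc1cc(=O)oc2cc(SCc3cccc(C(F)(F)F)c3)ccc12`, likewise sits at a limit, giving > 28500 nM (the limit of > 28500 nM in this assay, at which 1 of the 3 values shown sits). For the measured compounds named here, the one measured step between these compounds, an at least 3.7-fold lower number from compound 2 to compound 3 (0.56 log units; beyond the scatter), is the only guide to how a change on this ring moves the read-out.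

Compound 4 has the structure `Cc1cccc(CSc2ccc3c(C)cc(=O)oc3c2)c1`. It differs from compound 3 in this way: methyl in place of methoxycarbonyl on an aromatic carbon, the methyl sitting on an aromatic carbon of a six-membered aromatic ring of carbon only, meta to a large group. Going by the values given here, no measured step carries exactly this change; the nearest is the step from compound 2 to compound 3, in which the methoxycarbonyl arrived and the number fell. Since the methoxycarbonyl now leaves, a step back toward weaker inhibition is expected, and a limit rather than a number is a real possibility. Compound 4 is therefore estimated at 22000 nM, between 7000 nM and 60000 nM, which means an expected step of a 2.9-fold higher number from compound 3 to compound 4 (0.46 log units; beyond the scatter).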

Compound 4, concentration for 50% growth inhibition: > 33700 nM
Compound 4 gave a limit, no number; the forecaster's own chance of this, stated with the estimate: 50%; middle value at least 1.5-fold (0.18 log units) from the limit.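

In this assay, putting methyl on the aromatic carbon that carries methoxycarbonyl in compound 3 gave an at least 4.3-fold higher number from compound 3 to compound 4 (0.64 log units; beyond the scatter), so this change can now be read directly and not only through the earlier step from trifluoromethyl. For the compounds shown here, two different groups, trifluoromethyl in compound 2 and methyl in compound 4, have now each been set against methoxycarbonyl on this carbon, and both comparisons point to weaker inhibition of growth without methoxycarbonyl, which leaves compound 3 as the only one of the four compounds with a number. Compound 4 adds a limit and not a number: the limit of > 33700 nM in this assay, at which 1 of the 4 values shown sits.

The steps to compound 4 from compound 2 and from compound 1 join two limits and cannot be read, so these three compounds cannot be placed in any order. As far as these compounds go, it also remains open whether the whole methoxycarbonyl group is needed or only part of it, a question that a carboxylic acid, a primary amide or a nitrile on the same aromatic carbon would address, and how far compound 3 could be improved from its value of 7700 nM.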